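The source may hold more compounds than are shown below. What is called first, only, known or untested is meant among the compounds shown, and "the series" means these compounds.

Compound 1 `COc1ccc(Cn2c(C(=O)O)c(CNCc3cccc(OC)c3)c3ccccc32)cc1` is the weaker end of a short series; in a functional assay on Bel-7402 cells (Homo sapiens) for antiproliferative activity, read by MTT assay, with a stated time of 72 h (on this read-out lower numbers stand for stronger inhibition and higher numbers for weaker inhibition), compound 1 gives 52900 nM. Compound 2 `COc1cccc(CNCc2c(C(=O)O)n(Cc3ccc(O)cc3)c3ccccc23)c1` differs only by hydrogen in place of methyl on an oxygen on an aromatic ring. In this assay compound 2 returns > 50000 nM, which is a limit of the assay and not a number. The step that the limit leaves unreadable from compound 1 to compound 2 is therefore not readable in size because of the limit of > 50000 nM in this assay, at which 1 of the 2 values shown sits. Compound 3 `COc1cccc(CNCc2c(C(=O)O)n(Cc3ccc(F)cc3)c3ccccc23)c1` is the next member, and it differs from compound 2 by fluoro in place of hydroxy on an aromatic carbon. Within the data shown here, no measured step bears on this change, and the one step that exists is itself unreadable, so there is no basis to expect movement beyond the scatter. Both measured compounds sit at or near the top of the range, and compound 3 is expected to stay there as well. The step of a number no higher from compound 2 to compound 3 (the limit leaves the size open) is expected to be none beyond the scatter. Compound 3 is estimated at 50000 nM, between 20000 nM and 150000 nM.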

Compound 3, half-maximal inhibitory concentration: > 50000 nM
Compound 3: only a limit was reported (the forecaster's own chance of this, stated with the estimate: 60%); the middle value sits exactly at the limit.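

No step among compound 1, compound 2 and compound 3 can be read in this assay, because two of the values are limits and not numbers: the limit of > 50000 nM in this assay, at which 2 of the 3 values shown sit.

The compounds shown leave open whether hydroxy or fluoro in place of methoxy on this aromatic carbon shifts the value at all.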